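A few compounds are considered here, and "the series" means these few. Any claim that something is new, unique, unknown or untested is made for them only; others in the source may bear on it.

Working notes on the series.

Of the compounds shown here, three have been measured in a functional assay (Homo sapiens) for inhibition; on this read-out higher numbers stand for weaker inhibition and lower numbers for stronger inhibition. Compound 1 `CCCCOc1ccccc1/C=C/C(=O)c1ccc(OC)c(OC)c1OC` gives 52000 nM. Compound 2 `COc1ccc(C(=O)/C=C/c2ccccc2O)c(OC)c1OC` gives 9000 nM. Compound 3 `CCCCOc1ccc(C(=O)/C=C/c2cc(OC)cc(OC)c2)cc1` gives 52000 nM, the same number as compound 1 at the digits given. Among the measured compounds shown here, the one counted step is a 5.8-fold lower number from compound 1 to compound 2 (0.76 log units; beyond the scatter), the change being (hydrogen in place of butyl on an oxygen on an aromatic ring). Compound 4 `COc1cc(/C=C/C(=O)c2ccc(O)cc2)cc(OC)c1` differs from compound 3 by hydrogen in place of butyl on an oxygen on an aromatic ring, the same change at the same kind of place. How the core of compound 3 differs from the core of compound 1 is not broken down here.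

For the measured compounds named here, for compound 4 a step of a 4.3-fold lower number from compound 3 to compound 4 (0.64 log units; beyond the scatter) in this assay is expected, resting on the single earlier instance a 5.8-fold lower number from compound 1 to compound 2 (0.76 log units; beyond the scatter) with compound 2. The core difference is unresolved. The expected range is kept wide. Compound 4 is estimated at 12000 nM, between 4000 nM and 40000 nM.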

Compound 4, half-maximal inhibitory concentration: 14000 nM
Beside the measured number, compound 4's estimate is 1.2-fold (0.07 log units) below it, within the range that was stated.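

The new step, butoxy to hydroxy, gives a 3.7-fold lower number from compound 3 to compound 4 (0.57 log units; beyond the scatter) in this assay. Set beside the earlier step, the change carries over between these two cores in direction and, within the scatter, in size: the same change on two cores in this assay, a 5.8-fold lower number (0.76 log units; beyond the scatter) from compound 1 to compound 2 and a 3.7-fold lower number (0.57 log units; beyond the scatter) from compound 3 to compound 4, 1.6-fold (0.19 log units) apart, within the scatter of two such steps. This rests on two pairs only, so it says nothing about any other core, and it does not explain why the number falls on either core.

The compounds shown hold only butoxy or hydroxy at this place, so whether the step follows the loss of the butyl chain or the presence of the hydroxy remains open. An ethoxy group, a hexyloxy chain or an amine in the same place could separate the two readings.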